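Swapping an imidazole arm for a thiazolylmethylsulfanyl arm

This account rests on a few compounds, and the source may have more. Where it says the series, first, only, none or still open, it means among the compounds named here.

In an assay on cardiac atrium with histamine H2 receptor (Cavia porcellus) as the target (on this read-out lower numbers stand for smaller maximal responses and higher numbers for larger maximal responses), compound 2 `N=C(NCCCCc1c[nH]cn1)NCCCc1c[nH]cn1` gives 85.5%, the lower of the two numbers measured, though within the scatter of compound 1 `N=C(NCCCc1c[nH]cn1)NCCCc1nccs1`, which gives 87%. Compound 3 `N=C(NCCCc1c[nH]cn1)NCCSCc1nccs1` differs from compound 2 in one place: ((1,3-thiazol-2-yl)methyl)sulfanyl in place of 2-(1H-imidazol-4-yl)ethyl on a saturated chain carbon, two bonds along the chain from an amine nitrogen. Among the measured compounds shown here, only one measured step bears on this, a number 1.5 percentage points lower from compound 1 to compound 2 (within the scatter), which also exchanged an imidazolyl group for a thiazolyl group and stayed within the scatter, so no step beyond the scatter is expected here. Compound 3 is therefore estimated at 84%, with a range of 70% to 98%, an expected step of a number 1.5 percentage points lower from compound 2 to compound 3 (within the scatter).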

Compound 3, largest response reached (reported as maximal response), in percent of the reference or control that the assay uses: 91%
The estimate for compound 3 lay 7 percentage points below the measured number; the measured number falls inside the stated range.
By their numbers in this assay, from the lowest: compounds 2, 1 and 3 (each within the scatter of the next).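

In this assay, ((1,3-thiazol-2-yl)methyl)sulfanyl in place of 2-(1H-imidazol-4-yl)ethyl gives a number 5.5 percentage points higher from compound 2 to compound 3 (within the scatter) and in place of (1,3-thiazol-2-yl)methyl gives a number 4 percentage points higher from compound 1 to compound 3 (within the scatter) at this saturated chain carbon. This place therefore accepts a thiazole arm carrying sulfur, as well as one without it, with no step beyond the scatter. No measured evidence shown offers an explanation for this. From the compounds shown here alone, whether an amine or a carboxylic acid at this place would also stay within the scatter remains open, as does the outcome for a longer chain.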